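An Aryl Amide Replaces the Cyclopropyl on the Shared Core

A few compounds are considered here, and "the series" means these few. Any claim that something is new, unique, unknown or untested is made for them only; others in the source may bear on it.

Three amides of one core have been measured in an assay for binding affinity to 5-hydroxytryptamine receptor 1F (Homo sapiens), read by radioligand binding; a lower number here means a stronger inhibitor, a higher number a weaker inhibitor. Compound 2 `CN1CCC(c2c[nH]c3ccc(NC(=O)C4CC4)nc23)CC1` gives 9.8 nM, the lowest number shown, though its gap to compound 1 lies within the scatter; compound 1 `CCCCCC(=O)Nc1ccc2[nH]cc(C3CCN(C)CC3)c2n1` gives 13 nM, and compound 3 `CN1CCC(c2c[nH]c3ccc(NC(=O)C4CCCCC4)nc23)CC1` gives 20 nM. The steps are small: a 1.3-fold lower number from compound 1 to compound 2 (0.12 log units; within the scatter), a 1.5-fold higher number from compound 1 to compound 3 (0.19 log units; within the scatter) and a 2.0-fold higher number from compound 2 to compound 3 (0.31 log units; beyond the scatter). Compound 4 `Cc1ccc(C(=O)Nc2ccc3[nH]cc(C4CCN(C)CC4)c3n2)cc1` has not yet been measured; it differs from compound 2 by 4-methylphenyl in place of cyclopropyl on a carbonyl carbon. The measured steps bear on it only loosely, since none of them brings in an aromatic ring, and the largest, a 2.0-fold higher number from compound 2 to compound 3 (0.31 log units; beyond the scatter), is a modest rise. A similar modest rise is expected, so compound 4 is estimated at 20 nM, with a range of 6 nM to 70 nM. The expected step is a 2.0-fold higher number from compound 2 to compound 4 (0.31 log units; beyond the scatter).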

Compound 4, inhibition constant: 12 nM
Beside the measured number, compound 4's estimate is 1.7-fold (0.22 log units) above it; the range from low to high includes it.
By their numbers in this assay, from the lowest: compounds 2, 4, 1 and 3 (each within the scatter of the next, the first and the last beyond it).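

On a carbonyl carbon whose other neighbour is the amide-type nitrogen, an aromatic ring is tolerated in this assay as well as the saturated groups: the change to 4-methylphenyl gives a 1.2-fold higher number from compound 2 to compound 4 (0.09 log units; within the scatter) and also a 1.7-fold lower number from compound 3 to compound 4 (0.22 log units; within the scatter) and a 1.1-fold lower number from compound 1 to compound 4 (0.03 log units; within the scatter). Binding here therefore does not depend on the group being saturated, at least across these four amides. Nothing at hand explains this result. 

Going by these compounds, what remains open is whether the methyl on the phenyl ring matters, and whether an amine or a carboxylic acid on that ring would keep the number in this range.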